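The source may hold more compounds than are shown below. What is called first, only, known or untested is meant among the compounds shown, and "the series" means these compounds.

Compound 2 `CN(C)CCn1cc(S(=O)(=O)c2cc(Cl)cc(Cl)c2)c2cccnc21` stands second highest of the three numbers in a functional assay on HeLa cells for agonist activity at 5-hydroxytryptamine receptor 6 (Homo sapiens), read by immunoassay (on this read-out lower numbers stand for smaller maximal responses and higher numbers for larger maximal responses), where compound 2 gives 80%. Compound 1 `NCCn1cc(S(=O)(=O)c2ccc(F)cc2)c2cccnc21` gives 100% and compound 3 `NCCn1cc(S(=O)(=O)c2cc(Cl)cc(Cl)c2)c2cccnc21` gives 65%. Going by the values given here, the only step between compounds that differ in one place, a number 15 percentage points lower from compound 2 to compound 3 (beyond the scatter), alters the chain amine and not the aryl sulfone, so it does not bear directly on the present change. Compound 4 `CN(C)CCn1cc(S(=O)(=O)c2ccc(Cl)s2)c2cccnc21` differs from compound 2 at the sulfonyl sulfur: 5-chlorothiophen-2-yl in place of 3,5-dichlorophenyl on a sulfonyl sulfur. Among the compounds with values here, compound 1 and compound 3 carry different aryl groups on the sulfonyl sulfur, and their two numbers lie apart by more than the scatter, but no pair isolates a five-membered ring there. A small movement in either direction, or none beyond the scatter, is therefore expected for a number 5 percentage points higher from compound 2 to compound 4 (within the scatter). Compound 4 is estimated at 85%, within 65% to 100%.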

Compound 4, largest response reached (Emax), in percent of the reference or control that the assay uses: 93%
Compound 4: the middle estimate sits 8 percentage points below what was measured; the measured number falls inside the stated range.
By their numbers in this assay, from the lowest: compound 3; then compound 2; then compounds 4 and 1 (each within the scatter of the next).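

In this assay, 5-chlorothiophen-2-yl in place of 3,5-dichlorophenyl on the sulfonyl sulfur gives a number 13 percentage points higher from compound 2 to compound 4 (beyond the scatter) with the dimethylamino chain held constant. Going by these compounds alone, this is the first step to isolate the group at this place, and it shows that a five-membered aromatic ring carrying one chlorine keeps a high maximal response here. No measurement on hand accounts for the rise. Open, going by these compounds, is whether the exchange holds with the amino chain, and whether thiophen-2-yl without chlorine or 5-bromothiophen-2-yl behaves alike.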